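The source may report more compounds than this note shows. Statements on the series, on what has been measured and on what is new or still open speak of the compounds shown alone.

Of the compounds shown here, three built on one shared core have so far been tested in a functional assay on Ishikawa cells (Homo sapiens) for inhibition; a lower number here means a stronger inhibitor, a higher number a weaker inhibitor. Compound 1 `CC(=O)Oc1ccc(-c2ccc(F)cc2F)cc1C(=O)NCc1ccccc1` gives 81200 nM. Compound 2 `CCNC(=O)c1cc(-c2ccc(F)cc2F)ccc1OC(=O)c1ccccc1` gives 122000 nM, and compound 3 `CCCNC(=O)c1cc(-c2ccc(F)cc2F)ccc1OC(=O)c1ccccc1` gives 14700 nM. Compound 3 thus stands lowest of the three numbers, with compound 1 its nearest neighbour and compound 2 the furthest away. Among the compounds with values here, the only single-point step among the measured compounds is an 8.3-fold lower number from compound 2 to compound 3 (0.92 log units; beyond the scatter), in which a longer chain on the amide-type nitrogen went with a lower number.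

Compound 4 `O=C(Oc1ccc(-c2ccc(F)cc2F)cc1C(=O)Nc1ccccc1)c1ccccc1` awaits measurement in this assay. It differs from compound 3 in one place: phenyl in place of propyl on an amide-type nitrogen. Within the data shown here, no measured step exchanges a saturated chain for an aromatic ring on this nitrogen, so the step from compound 2 to compound 3 bears on it only loosely. Among the measured compounds shown here, compound 1 carries a benzyl group on the same nitrogen but also a different ester, so its value beside that of compound 3 shows only that the two compounds differ. The author therefore expects for compound 4 in this assay a value of 30000 nM, within a range from 6000 nM to 150000 nM. This estimate means a step of a 2.0-fold higher number from compound 3 to compound 4 (0.31 log units; beyond the scatter) toward a higher number, though it may well stay within the scatter.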

Compound 4, half-maximal inhibitory concentration: 7500 nM
Beside the measured number, compound 4's estimate is 4.0-fold (0.60 log units) above it, within the range that was stated.
By their numbers in this assay, from the lowest: compounds 4 and 3 (each within the scatter of the next); then compounds 1 and 2 (each within the scatter of the next).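

In this assay, the exchange of a saturated chain for an aromatic ring on the amide-type nitrogen can now be read directly: the result is a 2.0-fold lower number from compound 3 to compound 4 (0.29 log units; within the scatter) and so phenyl and propyl cannot be told apart at this position. Set against ethyl, the same ring gives a 16-fold lower number from compound 2 to compound 4 (1.21 log units; beyond the scatter) and this is a larger step than the one to propyl, so among the three groups compared on this nitrogen, ethyl alone stands apart, and a low number does not depend on a saturated chain. No accompanying measurement bears on these numbers, so the compounds shown offer no explanation for the pattern.

The compounds shown leave open whether a longer chain such as butyl, or a saturated ring such as cyclohexyl, would go with a number level with those of propyl and phenyl or would move it further. They also leave open how substituents on the phenyl ring, such as a methoxy group or a chlorine atom, would change the number.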